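Octyl Exchanged for 4-Fluorophenoxy on the Aryloxypropanone Tetrazole Series

The source may report more compounds than this note shows. Statements on the series, on what has been measured and on what is new or still open speak of the compounds shown alone.

Compound 2 `CCCCCCCCc1ccc(OC(C)C(=O)Cn2nnc(-c3ccc(Cl)cc3)n2)cc1` reaches only a limit in a physicochemical assay for lipophilicity, read by HPLC, tested at 5 mM (a higher number here means a more lipophilic compound, a lower number a more polar compound), giving > 8, so no number is known for it, and it sits at the limit of > 8 in this assay, at which 1 of the 2 values shown sits. Compound 3 `CC(Oc1ccc(Oc2ccc(F)cc2)cc1)C(=O)Cn1nnc(-c2ccc(Cl)cc2)n1` differs by 4-fluorophenoxy in place of octyl on an aromatic carbon. Compound 1 `CC(Oc1ccc(Oc2ccc(F)cc2)cc1)C(=O)Cn1nnc(-c2ccccc2)n1` carries the same 4-fluorophenoxy group and gives 5.3 in this assay. The step is expected to run downward and well beyond the scatter, as a number at least 2.10 log units lower from compound 2 to compound 3 (beyond the scatter) in this assay. Compound 3 is therefore expected near 5.9, within 5.3 to 6.5, because compound 1 with the same 4-fluorophenoxy group gives 5.3.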

Compound 3, partition coefficient: 6.2
For compound 3 the middle estimate is 0.30 log units below the measured one; the measured number falls inside the stated range.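

In this assay, 4-fluorophenoxy in place of octyl on an aromatic carbon gives a number at least 1.80 log units lower from compound 2 to compound 3 (beyond the scatter). Compound 2 gives only a limit, so this step has a floor and no known full size: the limit of > 8 in this assay, at which 1 of the 3 values shown sits. With 4-fluorophenoxy held constant, chloro in place of hydrogen on an aromatic carbon gives a number 0.90 log units higher from compound 1 to compound 3 (beyond the scatter).

As far as these compounds go, how a butyl chain, an amine or a carboxylic acid on that aromatic carbon would read in this assay remains open. Also open, from the compounds shown here alone, is whether the chloro step carries over when octyl replaces 4-fluorophenoxy.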